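One Chloro Less: From Compound 2 to Compound 4

The source may report more compounds than this note shows. Statements on the series, on what has been measured and on what is new or still open speak of the compounds shown alone.

Of the compounds shown here, three have so far been measured in a functional assay on DU-145 cells (Homo sapiens) for inhibition, read by trypan blue exclusion, with a stated time of 96 h; on this read-out higher numbers stand for weaker inhibition of growth and lower numbers for stronger inhibition of growth. Compound 1 `O=C(/C(=C\c1ccc(O)cc1)S(=O)(=O)Cc1ccc(Cl)c(Cl)c1)c1ccc(Cl)cc1` gives 10000 nM. Compound 2 `Cc1ccc(/C=C(\C(=O)c2ccc(Cl)cc2)S(=O)(=O)Cc2ccc(Cl)cc2Cl)s1` gives 10000 nM, and compound 3 `O=C(/C(=C\c1ccc(Cl)cc1)SCc1ccc(Cl)cc1)c1ccc(Br)cc1` gives 10000 nM. Compound 2 thus stands level with compounds 1 and 3; all three values lie within the usual scatter of one another, so no order among them can be read. Compound 4 `Cc1ccc(/C=C(\C(=O)c2ccc(Cl)cc2)S(=O)(=O)Cc2ccc(Cl)cc2)s1` has not yet been measured. It differs from compound 2 in one place (hydrogen in place of chloro on an aromatic carbon). Within the data shown here, no step between two measured compounds shows this change, and nothing in the three results points one way or the other. The step from compound 2 to compound 4 is expected to stay within the scatter, no change at the digits printed from compound 2 to compound 4 (within the scatter). Compound 4 is therefore estimated at 10000 nM, with a range from 4000 nM to 25000 nM.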

Compound 4, concentration for 50% growth inhibition: 1000 nM
Compound 4: the middle estimate sits 10-fold (1.00 log units) above what was measured; measured number below the stated range.
By their numbers in this assay, from the lowest: compound 4; then compounds 1, 2 and 3 (each within the scatter of the next).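

The earlier compounds shown here stood level, so they could not show whether any single position mattered. In this assay, this position does matter: going from 2,4-dichlorobenzyl to 4-chlorobenzyl gives a 10-fold lower number from compound 2 to compound 4 (1.00 log units; beyond the scatter), which means stronger inhibition of growth with hydrogen in place of chloro. No measurement at hand gives a cause for this step.

The compounds shown leave open how a fluoro, a methoxy or an amine at this position would compare with hydrogen and chloro. They also leave open whether the same change gives a similar step when other parts of the molecule differ.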